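This account rests on a few compounds, and the source may have more. Where it says the series, first, only, none or still open, it means among the compounds named here.

Compound 1 `C=C1C[C@@H](O)/C=C(\C)CC[C@@H](C(C)C)[C@@H](O)C1`: >= 10 ug/mL
Compound 2 `C/C1=C\[C@H](O)C[C@]2(C)O[C@H]2[C@H](O)[C@H](C(C)C)CC1`: >= 10 ug/mL
Compound 3 `CC(=O)O[C@H]1/C=C(\C)CC[C@@H](C(C)C)[C@@H](O)[C@@H]2O[C@@]2(C)C1`: not yet measured

In an ADME assay on cells (Macrophage, Mus musculus) for cytotoxicity, read by MTT assay, with a stated time of 24 h (on this read-out lower numbers stand for stronger inhibition and higher numbers for weaker inhibition), compound 1 gives >= 10 ug/mL, which is a limit of the assay and not a number. Compound 2 likewise gives only a limit, >= 10 ug/mL, so no exact value is known for it. Both measured compounds therefore sit at the same limit: the limit of >= 10 ug/mL in this assay, at which 2 of the 2 values shown sit.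

Compound 3 departs from compound 2 in one place: acetyl in place of hydrogen on an oxygen on a saturated carbon. Put simply, a hydroxy group of compound 2 becomes an acetoxy group in compound 3. Going by the values given here, no measured step shows what this change does in this assay. The expectation rests only on compound 2, whose limit is >= 10 ug/mL, and no change beyond the scatter is expected in either direction. The expected size of the change is a step that the limit leaves unreadable from compound 2 to compound 3. In this assay the estimate for compound 3 is 12 ug/mL, with an expected range of 5 ug/mL to 40 ug/mL.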

Compound 3, half-maximal inhibitory concentration: >= 10 ug/mL
Compound 3 ended at the assay's limit; the forecaster's own chance of this, stated with the estimate: 70%; the middle value is on the limit's open side.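

No step can be read from compound 2 to compound 3 in this assay, because both values are limits and not numbers: the limit of >= 10 ug/mL in this assay, at which 3 of the 3 values shown sit. As far as these compounds go, whether hydroxy to acetoxy changes the result in this assay at all, and in which direction, stays open.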